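The source may hold more compounds than are shown below. What is called first, only, known or untested is meant among the compounds shown, and "the series" means these compounds.

Measured in a functional assay on HeLa cells (Homo sapiens) for antiproliferative activity, read by MTT assay, with a stated time of 72 h; a lower number here means a stronger inhibitor, a higher number a weaker inhibitor:
Compound 1 `O=C1COc2ccc(-c3cccc(NS(=O)(=O)c4ccc(F)cc4)c3)cc2N1c1ccc(Cl)cc1`: 35000 nM
Compound 2 `O=C1COc2ccc(-c3cccc(NS(=O)(=O)c4ccc(F)cc4)c3)cc2N1c1ccccc1`: 17700 nM
Compound 3 `COc1ccc(N2C(=O)COc3ccc(-c4cccc(NS(=O)(=O)c5ccc(F)cc5)c4)cc32)cc1`: 13200 nM

Compound 3, at 13200 nM, cannot be separated from compound 2, as a 1.3-fold lower number from compound 2 to compound 3 (0.13 log units; within the scatter) shows. It is clearly separated only from compound 1, by a 2.7-fold lower number from compound 1 to compound 3 (0.42 log units; beyond the scatter). The remaining pair gives a 2.0-fold lower number from compound 1 to compound 2 (0.30 log units; within the scatter).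

The next compound is compound 4 `Cc1ccc(N2C(=O)COc3ccc(-c4cccc(NS(=O)(=O)c5ccc(F)cc5)c4)cc32)cc1`, which carries methyl in place of methoxy on an aromatic carbon, para to a large group (methyl in place of methoxy on an aromatic carbon). No exchange involving methyl has been measured in this series, so the evidence is indirect. The closest guide is the replacement of hydrogen by methoxy, a 1.3-fold lower number from compound 2 to compound 3 (0.13 log units; within the scatter), which is small. Going by the values given here, only the step from chloro to methoxy, a 2.7-fold lower number from compound 1 to compound 3 (0.42 log units; beyond the scatter), is modest in size. A small shift toward a higher number is therefore expected, and nothing beyond the scatter. The expected step is a 1.3-fold higher number from compound 3 to compound 4 (0.11 log units; within the scatter). Compound 4 is estimated at 17000 nM, with an expected range of 9000 nM to 32000 nM.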

Compound 4, half-maximal inhibitory concentration: > 40000 nM
Compound 4: a limit, no number (the forecaster's own chance of this, stated with the estimate: 10%); middle value at least 2.3-fold (0.37 log units) from the limit.
By their numbers in this assay, from the lowest: compounds 3, 2 and 1 (each within the scatter of the next, the first and the last beyond it). At a limit, above all of these: compound 4.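

Compound 4 in this assay gives > 40000 nM, a limit of the assay and not a number: the limit of > 40000 nM in this assay, at which 1 of the 4 values shown sits.

The earlier compounds had shown no separation between methoxy and hydrogen at this position, para to a large group, but the 4-methoxyphenyl to 4-methylphenyl change gives a step beyond the scatter (an at least 3.0-fold higher number from compound 3 to compound 4 (0.48 log units; beyond the scatter)), and methyl also stands clear of hydrogen (an at least 2.2-fold higher number from compound 2 to compound 4 (0.35 log units; beyond the scatter)). Against chloro the floor of the step lies within the scatter (an at least 1.1-fold higher number from compound 1 to compound 4 (0.05 log units; that floor lies within the scatter)), so the order of that pair stays unsettled.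

The compounds shown leave open whether an ethyl group, a hydroxyl or an amine at this position would stay in the range of the methoxy and hydrogen compounds or also reach the limit. They also leave open whether any group here gives a clearly lower number than methoxy does.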